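Isopropyl to methyl beside the ring nitrogen

The source may report more compounds than this note shows. Statements on the series, on what has been measured and on what is new or still open speak of the compounds shown alone.

Compound 1 `CCCCc1nc(C(C)C)c(CC(=O)OC2CC2)c(=O)n1Cc1ccc(-c2ccccc2-c2noc(=O)[nH]2)cc1`, compound 2 `CCCCc1nc(C(C)C)c(CC(=O)OC2CCCCC2)c(=O)n1Cc1ccc(-c2ccccc2-c2noc(=O)[nH]2)cc1` and compound 3 `CCCCc1nc(C(C)C)c(CC(=O)OC(CC)CC)c(=O)n1Cc1ccc(-c2ccccc2-c2noc(=O)[nH]2)cc1` share one core and differ only in the group on the ester oxygen. In an ADME assay on microsomes from liver (Mus musculus) for metabolic stability, with a stated time of 30 min (on this read-out lower numbers stand for a less stable compound and higher numbers for a more stable compound), compound 1 gives 11.4%, compound 2 gives 14.6% and compound 3 gives 14.6%. The steps are a number 3.2 percentage points higher from compound 1 to compound 2 (within the scatter), a number 3.2 percentage points higher from compound 1 to compound 3 (within the scatter) and no change at the digits printed from compound 2 to compound 3 (within the scatter); compound 2 matches compound 3 at the digits shown, and its step to compound 1 lies within the scatter. Compound 4 `CCCCc1nc(C)c(CC(=O)OC2CCCCC2)c(=O)n1Cc1ccc(-c2ccccc2-c2noc(=O)[nH]2)cc1` differs from compound 2 by methyl in place of isopropyl on an aromatic carbon. For the measured compounds named here, none of the measured steps touches this group; all three vary the ester oxygen substituent and none moves beyond the scatter. Going by the values given here, with no step bearing on the change, no movement beyond the scatter is expected: a number 0.6 percentage points lower from compound 2 to compound 4 (within the scatter). Compound 4 is estimated at 14%, with a range from 5% to 28%.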

Compound 4, percent of the compound remaining: 10.7%
Estimate against measurement, compound 4: 3.3 percentage points above; the range from low to high includes it.
By their numbers in this assay, from the lowest: compounds 4, 1, 2 and 3 (each within the scatter of the next).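

In this assay, for the compounds shown here, the first step at this position, methyl in place of isopropyl next to the ring nitrogen with the cyclohexyl ester held constant, gives a number 3.9 percentage points lower from compound 2 to compound 4 (within the scatter). Removing these two carbons from the group therefore produces no step beyond the scatter in this pair. No available evidence explains this result.

As far as these compounds go, whether the same exchange reads alike with the cyclopropyl or pentan-3-yl ester remains open. Also open, from the compounds shown here alone, is how a tert-butyl group or an amine at this position, or a carboxylic acid in place of the ester, would read.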